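Sulfur-free replacement on the shared core: expected step

This account rests on a few compounds, and the source may have more. Where it says the series, first, only, none or still open, it means among the compounds named here.

compound 1 `CC/N=C(\S)NCCCCCn1nc(-c2ccccc2)ccc1=O` gives 66.4% in a functional assay on the whole organism with Rattus norvegicus as the target, at a dose of 100 mg/kg; a higher number here means more inhibition at the dose given (going by the name of the read-out), a lower number less inhibition
compound 2 `C/N=C(/NC#N)NCCCCCCn1nc(-c2ccccc2)ccc1=O` gives 31.7%
compound 3 `CCC/N=C(/NC#N)NCCCCCn1nc(-c2ccccc2)ccc1=O` gives 27.5%

Compound 1 stands highest of the three, with compound 2 and compound 3 both beyond the scatter below it. Compound 4 `CN(C)/C(=N/CCCn1nc(-c2ccccc2)ccc1=O)NC#N` is not yet measured. The change from compound 1 is a group of 8 heavy atoms (4 carbon, 4 nitrogen; no ring) in place of a group of 8 heavy atoms (5 carbon, 2 nitrogen, 1 sulfur; no ring), on a saturated chain carbon, three bonds along the chain from an aromatic nitrogen. Within the data shown here, two measured steps bear on it: a number 34.7 percentage points lower from compound 1 to compound 2 (beyond the scatter) and a number 38.9 percentage points lower from compound 1 to compound 3 (beyond the scatter), each exchanging a group holding sulfur for one built only of carbon and nitrogen, and each a large fall. Between the two sulfur-free compounds, a number 4.2 percentage points lower from compound 2 to compound 3 (within the scatter) shows little separation. A large downward step in this assay is therefore expected for compound 4, though the shorter chain adds uncertainty. Compound 4 is estimated at 30%, range 10% to 50%. The expected step is a number 36.4 percentage points lower from compound 1 to compound 4 (beyond the scatter).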

Compound 4, a percentage reported as inhibition, in the whole organism at one dose (the size of the read-out at that dose, not a potency): 72.2%
Compound 4: the middle estimate sits 42.2 percentage points below what was measured, outside the stated range (above it).
By their numbers in this assay, from the lowest: compounds 3 and 2 (each within the scatter of the next); then compounds 1 and 4 (each within the scatter of the next).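

In this assay the step is a number 5.8 percentage points higher from compound 1 to compound 4 (within the scatter) and so, at this place, three bonds along the chain from an aromatic nitrogen, a sulfur-free group of 8 heavy atoms (4 carbon, 4 nitrogen) can stand in for the group holding sulfur. The steps of a number 34.7 percentage points lower from compound 1 to compound 2 (beyond the scatter) and a number 38.9 percentage points lower from compound 1 to compound 3 (beyond the scatter) thus do not follow from loss of sulfur alone. Nothing available explains this result.

The shorter chain and the dimethyl amine change together in compound 4, so neither can be credited alone. A longer chain carrying the dimethyl amine, or a monomethyl amine on the shorter chain, would separate them.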